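Removing One Methoxy Group: The Same Change on Two Cores

This account rests on a few compounds, and the source may have more. Where it says the series, first, only, none or still open, it means among the compounds named here.

Compound 1, `COc1cc(-c2cc(/C=C/C(=O)c3ccc(N)cc3)[nH]n2)cc(OC)c1OC`: 5590 nM
Compound 2, `COc1ccc(-c2cc(/C=C/C(=O)c3ccc(N)cc3)[nH]n2)cc1OC`: 16500 nM
Compound 3, `COc1cc(C(=O)/C=C/c2cc(-c3cc(OC)c(OC)c(OC)c3)n[nH]2)cc(OC)c1OC`: 4850 nM

All three were tested in a functional assay on NCI-H322M cells (Homo sapiens) for inhibition, read by sulforhodamine B assay, with a stated time of 48 h; on this read-out lower numbers stand for stronger inhibition of growth and higher numbers for weaker inhibition of growth. Compound 1 gives 5590 nM in this assay, and compound 2 gives 16500 nM. The two differ by hydrogen in place of methoxy on an aromatic carbon, and this change made a 3.0-fold higher number from compound 1 to compound 2 (0.47 log units; beyond the scatter). Compound 3 gives 4850 nM in this assay; this value and that of compound 1 lie within the scatter of each other, while compound 2 stands beyond it. The difference between the core of compound 3 and the core of compound 1 is not broken down here.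

Compound 4 `COc1ccc(-c2cc(/C=C/C(=O)c3cc(OC)c(OC)c(OC)c3)[nH]n2)cc1OC` has not yet been measured. It differs from compound 3 by hydrogen in place of methoxy on an aromatic carbon, the same change seen between compound 1 and compound 2, with the same surroundings around the place. That earlier change made a 3.0-fold higher number from compound 1 to compound 2 (0.47 log units; beyond the scatter), so a step of similar size is expected here, a 2.9-fold higher number from compound 3 to compound 4 (0.46 log units; beyond the scatter). On that basis compound 4 is estimated at 14000 nM, with a range from 6000 nM to 35000 nM.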

Compound 4, concentration for total growth inhibition: 6030 nM
Beside the measured number, compound 4's estimate is 2.3-fold (0.37 log units) above it; the measured number falls inside the stated range.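

On the second core, hydrogen in place of methoxy gave a 1.2-fold higher number from compound 3 to compound 4 (0.09 log units; within the scatter) in this assay, so on this core the change leaves no effect that can be told from the usual spread of repeated measurements. Set beside the step on the first core, this result does not differ from it by more than two such steps can scatter: the same change on two cores in this assay, a 3.0-fold higher number (0.47 log units; beyond the scatter) from compound 1 to compound 2 and a 1.2-fold higher number (0.09 log units; within the scatter) from compound 3 to compound 4, 2.4-fold (0.38 log units) apart, within the scatter of two such steps. The series therefore gives no evidence that the change behaves differently on the two cores, but it does not show that the step carries over at a fixed size, since one step lies beyond the scatter and the other within it, and a single pair per core cannot settle the matter.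

The compounds shown hold only methoxy or hydrogen at this place, so they leave open how a hydroxyl group, a fluorine atom or a longer alkoxy chain there would read. They also leave open whether the same comparison would hold on any core beyond these two.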